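Cytotoxicity notes on a naphthyl-tetrazole hydrazone series

The source may hold more compounds than are shown below. What is called first, only, known or untested is meant among the compounds shown, and "the series" means these compounds.

Measured so far:
compound 1 `O=C(CSc1nnnn1-c1cccc2ccccc12)N/N=C/c1ccc(Cl)cc1`: > 295000 nM
compound 2 `O=C(CSc1nnnn1-c1cccc2ccccc12)N/N=C/c1ccccc1Cl`: 69700 nM
compound 3 `Cc1cccc(/C=N/NC(=O)CSc2nnnn2-c2cccc3ccccc23)c1`: 269000 nM

In an ADME assay on MT4 cells (Homo sapiens) for cytotoxicity, read by MTT assay (a higher number here means that more compound is tolerated, a lower number that less compound is tolerated), compound 1 gives > 295000 nM, which is a limit of the assay and not a number. Compound 3 holds the highest of the two numbers, with compound 2 nearest at a 3.9-fold higher number from compound 2 to compound 3 (0.59 log units; beyond the scatter). Compound 4 `COc1cc(/C=N/NC(=O)CSc2nnnn2-c2cccc3ccccc23)ccc1O` differs from compound 3 by 4-hydroxy-3-methoxyphenyl in place of 3-methylphenyl on a carbon with a double bond to nitrogen. The measured steps all change the same aryl group: an at least 4.2-fold lower number from compound 1 to compound 2 (0.62 log units; beyond the scatter) and an at least 1.0-fold lower number from compound 1 to compound 3 (0.04 log units; that floor lies within the scatter), alongside a 3.9-fold higher number from compound 2 to compound 3 (0.59 log units; beyond the scatter). Only a chloro shift moved the number beyond the scatter, so for compound 4 no change beyond the scatter is expected in this assay, as a 1.1-fold lower number from compound 3 to compound 4 (0.05 log units; within the scatter). Compound 4 is thus estimated at 240000 nM, within 90000 nM to 300000 nM.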

Compound 4, half-maximal cytotoxic concentration: > 287000 nM
Compound 4 ended at the assay's limit (the forecaster's own chance of this, stated with the estimate: 40%); middle value at least 1.1-fold (0.07 log units) from the limit.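

In this assay, 4-hydroxy-3-methoxyphenyl on a carbon with a double bond to nitrogen gives an at least 1.0-fold higher number from compound 3 to compound 4 (0.02 log units; that floor lies within the scatter), so the oxygen-bearing aryl group shows no step beyond the scatter against 3-methylphenyl. Against 2-chlorophenyl it gives an at least 4.1-fold higher number from compound 2 to compound 4 (0.61 log units; beyond the scatter), which leaves compound 2 beyond the scatter from all three other compounds. Compound 4 gives a limit of the assay and not a number: the limit of > 287000 nM in this assay, at which 1 of the 4 values shown sits.

The step between compound 1 and compound 4 cannot be read, as both values are limits. On these data alone, whether an amine or a carboxylic acid on this aryl group would lower the number remains open.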